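The compounds below may be only part of what the source reports. "The series", "measured", "known", "first", "only" and "open" are said of these compounds alone.

Measured compounds:
Compound 1, `C/N=C(/NC#N)NCCCCCCn1nc(-c2ccccc2)ccc1=O`, in a functional assay on the whole organism with Rattus norvegicus as the target, at a dose of 100 mg/kg (on this read-out lower numbers stand for less inhibition and higher numbers for more inhibition at the one dose given (going by the name of the read-out)), compound 1 gives 31.7%.
Compound 2, `C/N=C(/NC#N)NCCCCCn1nc(-c2ccccc2)ccc1=O`, where compound 2 gives 47.6%.
Compound 3, `C/N=C(/NC#N)NCCCCCn1nc(-c2ccccc2)cc(C)c1=O`, where compound 3 gives 33.8%.

One change appears twice in this set. From compound 1 to compound 2 it is a group of 7 heavy atoms (3 carbon, 4 nitrogen; no ring) in place of a group of 8 heavy atoms (4 carbon, 4 nitrogen; no ring), on a saturated chain carbon, five bonds along the chain from an aromatic nitrogen, and it made a number 15.9 percentage points higher from compound 1 to compound 2 (beyond the scatter). From compound 2 to compound 3, methyl in place of hydrogen on an aromatic carbon made a number 13.8 percentage points lower from compound 2 to compound 3 (beyond the scatter). Compound 3 and compound 1 have the same atoms joined differently; the difference between the two cores is not broken down here.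

Compound 4, `C/N=C(/NC#N)NCCCCn1nc(-c2ccccc2)cc(C)c1=O`, has not been measured. Relative to compound 3 the change is a group of 7 heavy atoms (3 carbon, 4 nitrogen; no ring) in place of a group of 8 heavy atoms (4 carbon, 4 nitrogen; no ring), on a saturated chain carbon, four bonds along the chain from an aromatic nitrogen. It is the same kind of change as that from compound 1 to compound 2, but the place differs: four bonds along the chain from an aromatic nitrogen rather than five. Resting on a number 15.9 percentage points higher from compound 1 to compound 2 (beyond the scatter), compound 4 is expected to give a number 10.2 percentage points higher from compound 3 to compound 4 (beyond the scatter), with less confidence because the place is not identical. The estimate for compound 4 is 44%, between 26% and 60%.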

Compound 4, a percentage reported as inhibition, in the whole organism at one dose (the size of the read-out at that dose, not a potency): 68.6%
Compound 4: the middle estimate sits 24.6 percentage points below what was measured, outside the stated range (above it).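

In this assay, the group of 7 heavy atoms in place of the group of 8 made a number 34.8 percentage points higher from compound 3 to compound 4 (beyond the scatter). The direction of the change carried over from one core to the other, but its size did not: the same change on two cores in this assay, a number 15.9 percentage points higher (beyond the scatter) from compound 1 to compound 2 and a number 34.8 percentage points higher (beyond the scatter) from compound 3 to compound 4, 18.9 percentage points apart, beyond the scatter of two such steps. Two pairs cannot show whether this gap follows the core, with or without the methyl on the aromatic carbon, or the place of the change, four bonds along the chain from an aromatic nitrogen rather than five.

The compounds shown leave open whether an ethyl in place of that methyl would give a similar step. They also leave open how a still shorter chain, or an amine in place of the nitrile, would read in this assay.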